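Dimethylamino in place of methoxy on compound 3

This account rests on a few compounds, and the source may have more. Where it says the series, first, only, none or still open, it means among the compounds named here.

Of the compounds shown here, three have been measured so far. Compound 1 `C/C(=N\NC(=O)CC#N)c1ccc(S(=O)(=O)N2CCCCC2)cc1` is the smallest of them; in a functional assay on MCF7 cells (Homo sapiens) for cytotoxicity, read by sulforhodamine B assay, with a stated time of 48 h (on this read-out higher numbers stand for weaker inhibition and lower numbers for stronger inhibition), compound 1 gives 44200 nM. Compound 2 `CCOC(=O)c1c(-c2ccc(C)cc2)c(C#N)c(=O)n(/N=C(\C)c2ccc(S(=O)(=O)N3CCCCC3)cc2)c1N` adds the shared core, and in this assay compound 2 gives 37900 nM. Compound 3 `CCOC(=O)c1c(-c2ccc(OC)cc2)c(C#N)c(=O)n(/N=C(\C)c2ccc(S(=O)(=O)N3CCCCC3)cc2)c1N` carries methoxy in place of methyl on an aromatic carbon, and in this assay compound 3 gives 51200 nM. For the measured compounds named here, that change is the one measured step: a 1.4-fold higher number from compound 2 to compound 3 (0.13 log units; within the scatter). Compound 3 thus holds the highest of the three numbers, but its gaps to compound 1 and to compound 2 both fall within the scatter, so the three compounds cannot be put in order.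

Compound 4 `CCOC(=O)c1c(-c2ccc(N(C)C)cc2)c(C#N)c(=O)n(/N=C(\C)c2ccc(S(=O)(=O)N3CCCCC3)cc2)c1N` is the next candidate. Relative to compound 3 the change is dimethylamino in place of methoxy on an aromatic carbon, sitting on an aromatic carbon of a six-membered aromatic ring of carbon only, para to a large group. Going by the values given here, the only step that bears on this position is the exchange of methyl for methoxy, a 1.4-fold higher number from compound 2 to compound 3 (0.13 log units; within the scatter), which stayed within the scatter. On that basis the expected step is a 1.1-fold lower number from compound 3 to compound 4 (0.03 log units; within the scatter), no shift beyond the scatter. Compound 4 is therefore estimated at 48000 nM, with a range from 20000 nM to 115000 nM.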

Compound 4, half-maximal inhibitory concentration: 34400 nM
Estimate against measurement, compound 4: 1.4-fold (0.14 log units) above; the range from low to high includes it.
By their numbers in this assay, from the lowest: compounds 4, 2, 1 and 3 (each within the scatter of the next).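

In this assay, dimethylamino in place of methoxy on an aromatic carbon gives a 1.5-fold lower number from compound 3 to compound 4 (0.17 log units; within the scatter) and dimethylamino in place of methyl at that same place gives a 1.1-fold lower number from compound 2 to compound 4 (0.04 log units; within the scatter) as the second reading of this position. Until now the position had been read only with methyl and methoxy; with the 4-(dimethylamino)phenyl of compound 4 it has taken a third group, larger than either by its count of heavy atoms and attached through nitrogen, and each of the three steps among compounds 2, 3 and 4 still stays within the scatter, so this assay does not separate these three groups at this place. Nothing measured alongside these numbers speaks to the reason for this result.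

From the compounds shown here alone, what remains open is whether any group on this aromatic carbon can carry the number beyond the scatter, for example a carboxylic acid, a primary amine, a chlorine atom or a longer alkoxy chain. Also open, going by these compounds, is whether a change elsewhere on the shared core would do so, since all three steps here concern this single position.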